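Compound 3 to compound 4: phenyl in place of methoxy

The source may report more compounds than this note shows. Statements on the series, on what has been measured and on what is new or still open speak of the compounds shown alone.

Values measured in a functional assay on NCI-H460 cells (Homo sapiens) for cytotoxicity, read by MTT assay, with a stated time of 68 h (a higher number here means a weaker inhibitor, a lower number a stronger inhibitor), are these:
Compound 1 `COc1ccc(-c2cc(NC(=O)C(Cl)Cl)cc(-c3ccc(OC)cc3)c2)cc1` gives > 30000 nM as a limit
Compound 2 `COc1cccc(-c2cccc(NC(=O)C(Cl)Cl)c2)c1` gives 33800 nM as a number
Compound 3 `COc1ccc(-c2cccc(NC(=O)C(Cl)Cl)c2)cc1` gives 43300 nM as a number

Compound 1 stands at the limit of > 30000 nM in this assay, at which 1 of the 3 values shown sits, and so gives a limit and not a number. Compound 3 gives 43300 nM in this assay and compound 2 gives 33800 nM there, two values within the scatter of each other. Compound 4 `O=C(Nc1cccc(-c2ccc(-c3ccccc3)cc2)c1)C(Cl)Cl` differs from compound 3 by phenyl in place of methoxy on an aromatic carbon and so has phenyl in place of methoxy on an aromatic carbon, para to a large group. Among the compounds with values here, the one measured step that bears on this change is a step that the limit leaves unreadable from compound 1 to compound 3 and it concerns hydrogen in place of 4-methoxyphenyl. Its size cannot be read, so it offers no size to carry over, and no step beyond the scatter is expected in this assay for this change. The expected step is a 1.4-fold lower number from compound 3 to compound 4 (0.16 log units; within the scatter) by this estimate. For compound 4 the estimated value is 30000 nM with an expected range from 10000 nM to 80000 nM in this measurement.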

Compound 4, half-maximal inhibitory concentration: 10900 nM
Compound 4: the middle estimate sits 2.8-fold (0.44 log units) above what was measured, within the range that was stated.
By their numbers in this assay, from the lowest: compound 4; then compounds 2 and 3 (each within the scatter of the next).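

In this assay, within the data shown here, phenyl in place of methoxy on an aromatic carbon, para to a large group, gives a 4.0-fold lower number from compound 3 to compound 4 (0.60 log units; beyond the scatter), the first readable change of size at this position. Compounds 2 and 3, which carry methoxy in different places, lie within the scatter of each other, and the step from compound 1 to compound 3 cannot be read, so no earlier comparison had given a readable size. Nothing measured here accounts for this step.

This single pair leaves open whether the lower number needs an aromatic ring at this place, or whether an amine, a carboxylic acid or a longer chain there would give a similar value. It also leaves open whether phenyl would give a similar step at the place methoxy occupies in compound 2.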